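A few compounds are considered here, and "the series" means these few. Any claim that something is new, unique, unknown or untested is made for them only; others in the source may bear on it.

Compound 1 `CCN(CC)CCCn1c(N)c(-c2nc3ccccc3n2C)c2nc(C#N)c(C#N)nc21`, compound 2 `CN(C)CCCCn1c(N)c(-c2nc3ccccc3n2C)c2nc(C#N)c(C#N)nc21` and compound 3 `CCN(CC)CCn1c(N)c(-c2nc3cc(Cl)ccc3[nH]2)c2nc(C#N)c(C#N)nc21` were tested in a functional assay on Raji cells (Homo sapiens) for antiproliferative activity, read by MTT assay, with a stated time of 48 h; a lower number here means a stronger inhibitor, a higher number a weaker inhibitor. Compound 1 gives 2220 nM, compound 2 gives 320 nM, and compound 3 gives 31500 nM. The change (dimethylamino)methyl in place of diethylamino on a saturated chain carbon, three bonds along the chain from an aromatic nitrogen produced a 6.9-fold lower number from compound 1 to compound 2 (0.84 log units; beyond the scatter). The difference between the cores of compound 1 and compound 3 is not broken down here. Compound 4 `CN(C)CCCn1c(N)c(-c2nc3cc(Cl)ccc3[nH]2)c2nc(C#N)c(C#N)nc21` carries the change ((dimethylamino)methyl in place of diethylamino on a saturated chain carbon, two bonds along the chain from an aromatic nitrogen); the place now lies two bonds along the chain from an aromatic nitrogen instead of three, so this is the same kind of change, not the same one. The expected step is a 3.9-fold lower number from compound 3 to compound 4 (0.60 log units; beyond the scatter). This expectation rests on the step of a 6.9-fold lower number from compound 1 to compound 2 (0.84 log units; beyond the scatter), taken somewhat smaller since the place differs. Compound 4 is therefore estimated at 8000 nM in this assay, with a likely range from 2500 nM to 25000 nM.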

Compound 4, half-maximal inhibitory concentration: 3110 nM
For compound 4 the middle estimate is 2.6-fold (0.41 log units) above the measured one, within the range that was stated.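

In this assay, putting (dimethylamino)methyl in place of diethylamino gives a 10-fold lower number from compound 3 to compound 4 (1.01 log units; beyond the scatter), and this step can be set beside the earlier one on the other core: the same change on two cores in this assay, a 6.9-fold lower number (0.84 log units; beyond the scatter) from compound 1 to compound 2 and a 10-fold lower number (1.01 log units; beyond the scatter) from compound 3 to compound 4, 1.5-fold (0.16 log units) apart, within the scatter of two such steps

So the change carried over between these two cores in the same direction and by a similar amount, even though its place lies three bonds along the chain from an aromatic nitrogen in one pair and two bonds in the other. Two pairs do not show that it would carry over to further cores, and they do not explain why the number falls.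

Still open, going by these compounds, is whether a different amine, such as a pyrrolidine or a morpholine, would give a similar step. On these data alone, it is also open whether a longer chain would do so.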